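This account rests on a few compounds, and the source may have more. Where it says the series, first, only, none or still open, it means among the compounds named here.

Compounds measured so far in an assay on isolated protein for inhibition of adenosine deaminase (Bos taurus), with a stated time of 5 min; a higher number here means a weaker inhibitor, a lower number a stronger inhibitor:

compound 1, `C[C@H](O)[C@@H](CCc1ccccc1C(F)(F)F)n1cnc2c(N)ncnc21`: 6.2 nM
compound 2, `C[C@H](O)[C@@H](CCc1cccc(Br)c1)n1cnc2c(N)ncnc21`: 0.6 nM
compound 3, `C[C@H](O)[C@@H](CCC1CCCCC1)n1cnc2c(N)ncnc21`: 1.9 nM

Compound 2 gives the lowest number of the three in this assay; compound 3 stands nearest to it and compound 1 furthest, each beyond the scatter. Compound 4, `C[C@H](O)[C@@H](CCc1cccc(C(=O)O)c1)n1cnc2c(N)ncnc21`, is not yet measured. It differs from compound 2 in one place: carboxy in place of bromo on an aromatic carbon.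

Going by the values given here, only one single-site step has been measured: a 3.2-fold higher number from compound 2 to compound 3 (0.50 log units; beyond the scatter), which exchanges the whole ring and says nothing directly about a carboxy group on the ring. Among the compounds with values here, compound 1 carries a trifluoromethyl on its ring and gives 6.2 nM against compound 2 at 0.6 nM; no single step links the two, and the substituent and its place both differ. Within the data shown here, no measured step covers the change to a carboxy group, so the expectation leans on the spread of the three values alone. A modest rise in the number, as the step from compound 2 to compound 4 is expected to be an 8.3-fold higher number from compound 2 to compound 4 (0.92 log units; beyond the scatter), seems the likeliest outcome. For compound 4 in this assay the expected value is 5 nM, with a range from 1.2 nM to 25 nM.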

Compound 4, inhibition constant: 53 nM
The estimate for compound 4 lay 11-fold (1.03 log units) below the measured number; measured number above the stated range.
By their numbers in this assay, from the lowest: compound 2; then compound 3; then compound 1; then compound 4.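

In this assay the exchange of bromo for carboxy gives an 88-fold higher number from compound 2 to compound 4 (1.95 log units; beyond the scatter) and is a much larger step than a 3.2-fold higher number from compound 2 to compound 3 (0.50 log units; beyond the scatter) where cyclohexyl replaces the whole 3-bromophenyl. Going by these compounds alone, a change of one substituent on this aromatic carbon, meta to a large group, therefore moves the number further than exchanging the entire ring does, which the earlier compounds could not show. The carboxy group brings a hydrogen-bond donor and a hydrogen-bond acceptor where bromo has neither, but no measurement at hand ties the step to these or to any other feature of the group.

The compounds shown leave open whether a methyl ester or a primary amide on the same aromatic carbon would give a step of similar size. They also leave open whether carboxy on a different ring carbon would cost as much.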